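The source may report more compounds than this note shows. Statements on the series, on what has been measured and on what is new or still open speak of the compounds shown alone.

Measured in a physicochemical assay for solubility, at pH 2; on this read-out lower numbers stand for lower solubility and higher numbers for higher solubility:
- Compound 1 `CS(=O)(=O)c1ccc(-c2cnc3ccc(-c4cccc(C(=O)N5CCC(O)CC5)c4)nn23)cc1`: > 200000 nM
- Compound 2 `C[S+]([O-])c1cccc(-c2ccc3ncc(-c4ccc(S(C)(=O)=O)cc4)n3n2)c1`: 188000 nM

Among the compounds with values here, compound 2, at 188000 nM, holds the only true number in this assay. The entry for compound 1 is a limit, as the limit of > 200000 nM in this assay, at which 1 of the 2 values shown sits, records.

Compound 3 `C[S+]([O-])c1ccc(-c2cnc3ccc(-c4cccc([S+](C)[O-])c4)nn23)cc1` differs from compound 2 at one group: a group of 3 heavy atoms (1 carbon, 1 oxygen, 1 sulfur; no ring) in place of a group of 4 heavy atoms (1 carbon, 2 oxygen, 1 sulfur; no ring), on an aromatic carbon. The methylsulfonyl leaves a six-membered aromatic ring of carbon only, para to a large group. Within the data shown here, the one measured step, an at least 1.0-fold lower number from compound 1 to compound 2 (0.02 log units; that floor lies within the scatter), concerns a different group and is only a floor, so it sets no size. The expected step is a 1.0-fold higher number from compound 2 to compound 3 (0.00 log units; within the scatter), with none expected beyond the scatter. The estimate for compound 3 is 190000 nM, expected within 95000 nM to 380000 nM.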

Compound 3, solubility: 205000 nM
For compound 3 the middle estimate is 1.1-fold (0.03 log units) below the measured one, and the stated range covers the measured number.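

In this assay, the methylsulfonyl para to a large group gives way to a smaller group of 3 heavy atoms, with one hydrogen-bond acceptor fewer, and this yields a 1.1-fold higher number from compound 2 to compound 3 (0.04 log units; within the scatter). Unlike the earlier step, which was only a floor and concerned a different group, this one has a size, so exchanging these two sulfur groups at this position left the read-out within the scatter.

From the compounds shown here alone, whether an amine or a carboxylic acid at this position would move the number beyond the scatter stays open. Compound 1 remains a limit, so any comparison with it stays unsized: the limit of > 200000 nM in this assay, at which 1 of the 3 values shown sits.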